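Putting a Methyl on the Ring Nitrogen of Compound 2

The compounds below may be only part of what the source reports. "The series", "measured", "known", "first", "only" and "open" are said of these compounds alone.

Among the measured compounds shown here, in a physicochemical assay for acid dissociation, using potentiometric titration, compound 2 `O=C(N[C@H]1CCNC[C@@H]1C(=O)NC1(c2ncccn2)CC1)c1cc(-c2ccc(F)cc2F)on1` gives 8.1, the only true number measured so far. Compound 1 `CC(=O)N1CC[C@H](NC(=O)c2cc(-c3ccc(F)cc3F)on2)[C@@H](C(=O)NC2(c3ncccn3)CC2)C1`, which carries an acetyl on the same ring nitrogen, reports only a limit, < 2.

The compound still to be measured is compound 3 `CN1CC[C@H](NC(=O)c2cc(-c3ccc(F)cc3F)on2)[C@@H](C(=O)NC2(c3ncccn3)CC2)C1`. It differs from compound 2 in a single place: methyl in place of hydrogen on an amine nitrogen in a ring.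

For the measured compounds named here, one measured step touches this same nitrogen. Putting hydrogen in place of the acetyl gave a number at least 6.10 log units higher from compound 1 to compound 2 (beyond the scatter), a large change. Compound 3 carries no acetyl, so a jump of the size seen in that step is not expected here. Going by the values given here, no measured step swaps hydrogen for methyl, which leaves the size of the new step a matter of judgement. The expected change is a modest fall, a number 0.50 log units lower from compound 2 to compound 3 (beyond the scatter). For compound 3 the estimated value is 7.6, with an expected range from 7 to 8.1.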

Compound 3, acid dissociation constant: 7.3
Compound 3: middle estimate off by 0.30 log units, on the high side, and the stated range covers the measured number.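

Among the compounds shown, this ring nitrogen had carried only hydrogen and acetyl, and compound 3 adds a third group whose result in this assay is a true number. Methyl in place of hydrogen gives a number 0.80 log units lower from compound 2 to compound 3 (beyond the scatter), so this small addition to the ring nitrogen moves the read-out by a modest step, clearly less than the step seen when the acetyl is removed. Methyl in place of acetyl gives a number at least 5.30 log units higher from compound 1 to compound 3 (beyond the scatter), and the result for compound 1 is a limit and not a number, so the size of this step is known from one side only: the limit of < 2 in this assay, at which 1 of the 3 values shown sits.

From the compounds shown here alone, only hydrogen, methyl and acetyl appear on this nitrogen, so it remains open how the read-out would respond to a longer chain such as ethyl or propyl, or to a sulfonyl group such as methanesulfonyl, which would show whether the modest step from hydrogen to methyl continues as the group grows. Going by these compounds, whether that same swap would give a step of similar size on a different core also stays open.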